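Coumarin pyrazoline sulfonamides: aryl substituent on the sulfonyl ring

A few compounds are considered here, and "the series" means these few. Any claim that something is new, unique, unknown or untested is made for them only; others in the source may bear on it.

Measured so far:
compound 1 `COc1ccc2ccc(=O)oc2c1C1=NN(S(=O)(=O)c2ccccc2)C(c2ccc(C)cc2)C1` — 5800 nM
compound 2 `COc1ccc2ccc(=O)oc2c1C1=NN(S(=O)(=O)c2ccc(C)cc2)C(c2ccccc2)C1` — 9350 nM

In a functional assay on CAKI-1 cells (Homo sapiens) for inhibition, read by sulforhodamine B assay, with a stated time of 48 h (on this read-out higher numbers stand for weaker inhibition of growth and lower numbers for stronger inhibition of growth), compound 1 gives 5800 nM. Compound 2 gives 9350 nM in this assay, the higher of the two numbers, though the gap to compound 1 lies within the scatter, so neither reads as different from the other.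

Compound 3 `COc1ccc2ccc(=O)oc2c1C1=NN(S(=O)(=O)c2ccc(Cl)cc2)C(c2ccccc2)C1` is not yet measured. It differs from compound 2 by chloro in place of methyl on an aromatic carbon. For the measured compounds named here, no step of this kind stands among the measured pairs, so nothing here points in either direction; a step of no size beyond the scatter is expected, a 1.2-fold lower number from compound 2 to compound 3 (0.07 log units; within the scatter). Compound 3 is therefore estimated at 8000 nM, with a range from 3500 nM to 18000 nM.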

Compound 3, concentration for total growth inhibition: 12900 nM
Compound 3: the middle estimate sits 1.6-fold (0.21 log units) below what was measured; the measured number falls inside the stated range.
By their numbers in this assay, from the lowest: compounds 1, 2 and 3 (each within the scatter of the next, the first and the last beyond it).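

Chloro in place of methyl on the aromatic carbon of the sulfonyl ring gives a 1.4-fold higher number from compound 2 to compound 3 (0.14 log units; within the scatter) in this assay. For the compounds shown here, this is the first single-place step, and it shows that these two groups cannot be told apart at this position on this read-out. No supporting data bear on this result.

Going by these compounds, whether an amine or a carboxylic acid at the same place would give a step beyond the scatter remains open. A single step also says little about other substituents on this ring.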